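The source may report more compounds than this note shows. Statements on the series, on what has been measured and on what is new or still open speak of the compounds shown alone.

In a functional assay on BXPC-3 cells (Homo sapiens) for inhibition, read by MTT assay, with a stated time of 72 h (on this read-out higher numbers stand for weaker inhibition of growth and lower numbers for stronger inhibition of growth), compound 3 `CN(CCCNS(=O)(=O)c1cc(C(F)(F)F)cc(C(F)(F)F)c1)Cc1ccccc1` gives 39000 nM and stands highest of the three numbers measured; compound 1 `O=S(=O)(NCCCNCc1cccc2ccccc12)c1cc(C(F)(F)F)cc(C(F)(F)F)c1` gives 2700 nM and compound 2 `COc1cccc(CNCCCNS(=O)(=O)c2cc(C(F)(F)F)cc(C(F)(F)F)c2)c1` gives 1700 nM, both lower by amounts beyond the scatter. Compound 4 `COc1ccccc1CNCCCNS(=O)(=O)c1cc(C(F)(F)F)cc(C(F)(F)F)c1` differs from compound 3 by (2-methoxybenzyl)amino in place of benzyl(methyl)amino on a saturated chain carbon, three bonds along the chain from a sulfonamide nitrogen. The step that bears on this is a 23-fold higher number from compound 2 to compound 3 (1.36 log units; beyond the scatter), which runs the opposite way; the change from compound 1 to compound 2 was a 1.6-fold lower number from compound 1 to compound 2 (0.20 log units; within the scatter). A large step back down in this assay is therefore expected, with the number for compound 4 estimated near that of compound 2, giving a 16-fold lower number from compound 3 to compound 4 (1.19 log units; beyond the scatter). Compound 4 is thus expected to give about 2500 nM, with a range from 1000 nM to 7000 nM.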

Compound 4, concentration for 50% growth inhibition: 1700 nM
Compound 4: the middle estimate sits 1.5-fold (0.17 log units) above what was measured; measured number inside the range.
By their numbers in this assay, from the lowest: compounds 2, 4 and 1 (each within the scatter of the next); then compound 3.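

In this assay the (2-methoxybenzyl)amino group recovers what was lost with benzyl(methyl)amino at this saturated chain carbon, giving a 23-fold lower number from compound 3 to compound 4 (1.36 log units; beyond the scatter) on the way back. Shifting the methoxy group on the ring changes nothing that can be seen, with no change at the digits printed from compound 2 to compound 4 (within the scatter) for that pair, and 2-methoxyphenyl performs like naphthalen-1-yl, with a 1.6-fold lower number from compound 1 to compound 4 (0.20 log units; within the scatter) for that pair. Compound 3 therefore stands alone among the four compounds.

Compound 3 differs from compound 4 both in its methyl on nitrogen and in lacking the methoxy group, so only a plain benzylamino group could separate these two changes. Nothing measured here explains the result.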